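Amine-nitrogen substituent series, compound 4 pending

The compounds below may be only part of what the source reports. "The series", "measured", "known", "first", "only" and "open" are said of these compounds alone.

Measured compounds:
compound 1, `CC(C)N1CCN(Cc2csc(N)c2C(=O)c2ccc(Cl)cc2)CC1`, 0%
compound 2, `Nc1scc(CN2CCN(c3ccccc3C(F)(F)F)CC2)c1C(=O)c1ccc(Cl)cc1`, 0%
compound 3, `Nc1scc(CN2CCN(c3ccncc3)CC2)c1C(=O)c1ccc(Cl)cc1`, 2%

All three compounds share one core and differ only in the group on an amine nitrogen in a ring. In an assay on CHO cells for displacement of a labelled ligand from adenosine receptor A3 (Homo sapiens), read by scintillation counting, with a stated time of 120 min, tested at 10 uM (on this read-out higher numbers stand for more inhibition at the one concentration tested (going by the name of the read-out) and lower numbers for less inhibition), compound 1 gives 0%, compound 2 gives 0% and compound 3 gives 2%. The three numbers sit together: a number 2 percentage points higher from compound 1 to compound 3 (within the scatter), a number 2 percentage points higher from compound 2 to compound 3 (within the scatter) and no change at the digits printed from compound 1 to compound 2 (within the scatter). Compound 3 therefore does not separate from either of the other two; nothing in this set shows displacement beyond the scatter.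

Compound 4, `Nc1scc(CN2CCN(C3CCCC3)CC2)c1C(=O)c1ccc(Cl)cc1`, is the next member. Its change from compound 3 is cyclopentyl in place of pyridin-4-yl on an amine nitrogen in a ring.

All three measured steps bear on this position, and every one of them was flat: a carbon-only group, a substituted phenyl and a pyridine gave the same outcome. Compound 1, which also carries a carbon-only group at this nitrogen, gives 0% in this assay. The expectation for compound 4 is therefore a number 1 percentage points lower from compound 3 to compound 4 (within the scatter), with no step beyond the scatter in either direction. Compound 4 is estimated at 1% in this assay, within a range of -8% to 10%.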

Compound 4, a percentage reported as inhibition, at one concentration (the size of the read-out at that concentration, not a potency): 3%
For compound 4 the middle estimate is 2 percentage points below the measured one; the measured number falls inside the stated range.
By their numbers in this assay, from the lowest: compounds 1, 2, 3 and 4 (each within the scatter of the next).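

In this assay, among the compounds shown here, the change to cyclopentyl gives a number 1 percentage points higher from compound 3 to compound 4 (within the scatter) while the comparisons with the other two groups give a number 3 percentage points higher from compound 2 to compound 4 (within the scatter) and a number 3 percentage points higher from compound 1 to compound 4 (within the scatter) so no step at this position leaves the scatter. The set at this nitrogen now includes a five-membered non-aromatic ring of carbon only, which replaces a six-membered aromatic ring with 1 hetero atom and 1 hydrogen-bond acceptor without separating compound 4 from compound 3. Across compound 1, compound 2, compound 3 and compound 4, isopropyl, 2-(trifluoromethyl)phenyl, pyridin-4-yl and cyclopentyl therefore cannot be told apart by this read-out, and none of them shows displacement beyond the scatter.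

A carboxylic acid, an amide or an amine at the end of a longer chain on this nitrogen lies outside the compounds shown, so the outcome with such groups stays open. The shared core is constant in all four compounds, which leaves open whether a change elsewhere in it would alter the read-out at this receptor. No measurement at hand offers an explanation for the flat outcome at this position.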